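Benzimidazole-free notes: acetic acid thioethers at the receptor

This account rests on a few compounds, and the source may have more. Where it says the series, first, only, none or still open, it means among the compounds named here.

Measured compounds:
compound 1, `O=C(O)Cn1c(SCCCCOc2ccccc2)nc2ccccc21`, 1400 nM
compound 2, `CCCCCSc1nc2ccccc2n1CC(=O)O`, 1240 nM
compound 3, `CCOC(=O)CCCCCSc1nc2ccccc2n1CC(=O)O`, 1010 nM

In an assay on HEK293 cells for displacement of a labelled ligand from prostaglandin D2 receptor 2 (Homo sapiens) (a lower number here means a stronger inhibitor, a higher number a weaker inhibitor), compound 2 gives 1240 nM, the second highest of the three numbers; its nearest neighbour is compound 1 with 1400 nM and the furthest compound 3 with 1010 nM, and neither gap is beyond the scatter.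

Compound 4, `O=C(O)Cn1c(SCc2ccccc2Br)nc2ccccc21`, differs from compound 2 thus: 2-bromophenyl in place of butyl on a saturated chain carbon bound to a sulfur.

The three measured steps, a 1.1-fold lower number from compound 1 to compound 2 (0.05 log units; within the scatter), a 1.4-fold lower number from compound 1 to compound 3 (0.14 log units; within the scatter) and a 1.2-fold lower number from compound 2 to compound 3 (0.09 log units; within the scatter), all change the chain at its far end and all stay within the scatter. Within the data shown here, none of them touches the saturated chain carbon bound to the sulfur, and none exchanges butyl for an aromatic ring, so the step to compound 4 has no direct precedent here. With every measured change leaving the number essentially unmoved, the expectation for this assay is a step of a 1.1-fold lower number from compound 2 to compound 4 (0.05 log units; within the scatter), not beyond the scatter in either direction, with wide uncertainty. Compound 4 is therefore estimated at 1100 nM, with a range from 300 nM to 4000 nM.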

Compound 4, half-maximal inhibitory concentration: 580 nM
The estimate for compound 4 lay 1.9-fold (0.28 log units) above the measured number, and the stated range covers the measured number.
By their numbers in this assay, from the lowest: compounds 4, 3, 2 and 1 (each within the scatter of the next, the first and the last beyond it).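

In this assay, 2-bromophenyl in place of butyl on the saturated chain carbon bound to a sulfur gives a 2.1-fold lower number from compound 2 to compound 4 (0.33 log units; beyond the scatter) as the only step shown here that passes the scatter, and only modestly. Changes at the far end of the chain, among compound 1, compound 2 and compound 3, left the number within the scatter, whereas this aromatic ring on the chain carbon bound to the sulfur moves it. No measurement available here bears on the reason for this step.

With a single aromatic example, the contributions of the ring and the bromine cannot be separated: plain phenyl, or chlorine in place of the bromine, would begin to divide them. Also open, going by these compounds, is whether a longer chain between the sulfur and the ring, or an amine on that ring, would keep the step.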